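Moving one methoxy group on compound 2

This account rests on a few compounds, and the source may have more. Where it says the series, first, only, none or still open, it means among the compounds named here.

Values in a functional assay on HeLa cells (Homo sapiens) for cytotoxicity, read by WST assay, with a stated time of 48 h (on this read-out higher numbers stand for weaker inhibition and lower numbers for stronger inhibition), for the measured compounds
compound 1 `COc1ccc([C@@H]2OC[C@H]([C@@H](O)c3ccc(OC)c(OC)c3)C[C@H]2C/C=C/c2ccc(OC)c(OC)c2)cc1` gives 29200 nM
compound 2 `COc1ccc([C@H](O)[C@H]2CO[C@H](c3ccc(OC)c(OC)c3)[C@@H](C/C=C/c3ccc(OC)c(OC)c3)C2)cc1` gives 46000 nM
compound 3 `Oc1ccc(/C=C/C[C@H]2C[C@@H]([C@@H](O)c3ccccc3)CO[C@@H]2c2ccccc2)cc1` gives 14400 nM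

Compound 2 (46000 nM) and compound 1 (29200 nM) lie within the usual scatter of each other. Compound 3 (14400 nM) has a lower number than compound 2, a gap beyond the scatter. Compound 4 `COc1cccc([C@H](O)[C@H]2CO[C@H](c3ccc(OC)c(OC)c3)[C@@H](C/C=C/c3ccc(OC)c(OC)c3)C2)c1` keeps everything in compound 2 except one group: 3-methoxyphenyl in place of 4-methoxyphenyl on a saturated chain carbon bound to an oxygen on a saturated carbon and a saturated ring carbon. Among the compounds with values here, no measured pair shows this kind of change, so no shift beyond the scatter is expected in this assay (a 1.2-fold lower number from compound 2 to compound 4 (0.08 log units; within the scatter)). Compound 4 is estimated at 38000 nM (expected range 16000 nM to 85000 nM).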

Compound 4, half-maximal inhibitory concentration: 21200 nM
Compound 4: the middle estimate sits 1.8-fold (0.25 log units) above what was measured, and the stated range covers the measured number.
By their numbers in this assay, from the lowest: compounds 3, 4, 1 and 2 (each within the scatter of the next, the first and the last beyond it).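

In this assay, replacing 4-methoxyphenyl with 3-methoxyphenyl gives a 2.2-fold lower number from compound 2 to compound 4 (0.34 log units; beyond the scatter). Within the data shown here, this is the first comparison here that changes only one place, and it shows that moving the methoxy group on this ring can alter the number beyond the scatter, even though the atoms and the counted features of the group stay the same. The data offer no explanation for this shift. Still open, from the compounds shown here alone, is how an amine or a carboxylic acid in place of this methoxy group would affect the number.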